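A few compounds are considered here, and "the series" means these few. Any claim that something is new, unique, unknown or untested is made for them only; others in the source may bear on it.

Among the compounds with values here, in a functional assay on NCI-H460 cells (Homo sapiens) for cytotoxicity, read by MTT assay, with a stated time of 48 h (a lower number here means a stronger inhibitor, a higher number a weaker inhibitor), compound 2 (`COc1cc2c(=O)cc(-c3ccccc3F)[nH]c2cc1O`) gives 4400 nM as the lower of the two numbers so far. Compound 1 (`O=c1cc(-c2ccc(F)cc2)[nH]c2ccc(O)c(O)c12`) gives 100000 nM in this series. The gap between these two compounds lies beyond the scatter. Compound 3 (`COc1cc2c(=O)cc(-c3ccc(F)cc3)[nH]c2cc1O`) differs from compound 2 by 4-fluorophenyl in place of 2-fluorophenyl on an aromatic carbon with 4-fluorophenyl in place of 2-fluorophenyl on an aromatic carbon next to the ring nitrogen. Compound 1 also carries 4-fluorophenyl and stands at 100000 nM but differs elsewhere from compound 3, so only a modest rise in this assay is expected. The expected change is a 1.6-fold higher number from compound 2 to compound 3 (0.20 log units; within the scatter) toward weaker inhibition. For compound 3 the estimate is 7000 nM with an expected range of 1800 nM to 30000 nM for the measurement.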

Compound 3, half-maximal inhibitory concentration: > 100000 nM
Compound 3: only a limit was reported; the forecaster's own chance of this, stated with the estimate: 10%; at least 14-fold (1.15 log units) between middle value and limit.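

In this assay the swap of 2-fluorophenyl for 4-fluorophenyl on the aromatic carbon next to the ring nitrogen gives an at least 22-fold higher number from compound 2 to compound 3 (1.35 log units; beyond the scatter) on the same atoms, joined differently. At this position, then, the placement of fluorine on the phenyl ring alone carries a large step on the shared core. Compound 3 gives > 100000 nM as a limit of the assay and not a number, so the full size of the step stays undefined.

Still open, as far as these compounds go, is how an unsubstituted phenyl or a pyridyl group at this position would compare with 2-fluorophenyl.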